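The source may hold more compounds than are shown below. What is called first, only, known or untested is meant among the compounds shown, and "the series" means these compounds.

Series notes, a functional assay on the whole organism for antagonist activity, with Mus musculus as the target, in the maximal electroshock model; a higher number here means that more compound is needed for the effect, a lower number that less compound is needed:

- compound 1 `CCS(=O)(=O)c1nnc(-c2ccccc2)n1C`: a limit of the assay, > 200 mg/kg
- compound 2 `CCS(=O)(=O)c1nnc(-c2ccccc2F)n1C`: a limit of the assay, > 200 mg/kg
- compound 3 `Cn1nc(-c2ccccc2)nc1S(C)(=O)=O`: a limit of the assay, > 200 mg/kg

Compound 3 and compound 1 differ in more than one place; the difference between the two cores is not broken down here. The unmeasured member is compound 4 `Cn1nc(-c2cccc(F)c2)nc1S(C)(=O)=O`.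

Within the data shown here, the only change made twice in the set is fluoro in place of hydrogen on an aromatic carbon. Among the measured compounds shown here, its one measured step, a step that the two limits leave unreadable from compound 1 to compound 2, cannot be read, since both ends sit on the limit. The same kind of change leads from compound 3 to compound 4, (fluoro in place of hydrogen on an aromatic carbon), but the place differs: in the pair from compound 1 to compound 2 the fluoro sits ortho to a large group, in the pair from compound 3 to compound 4 it sits meta to a large group. What the measured values offer is the limit of > 200 mg/kg in this assay, at which 3 of the 3 values shown sit; no readable step in this assay exists anywhere in the set.

For the measured compounds named here, the expectation for compound 4 therefore rests only on the fact that compound 3 sits at > 200 mg/kg and that the one measured instance of this change left compound 2 at the same limit. The step from compound 3 to compound 4 is expected to be a step that the limit leaves unreadable from compound 3 to compound 4 in this assay, that is, no detectable movement. For compound 4 the estimate in this assay is 250 mg/kg, most likely reported again as a limit rather than a number, between 100 mg/kg and 600 mg/kg.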

Compound 4, dose for half-maximal effect: > 100 mg/kg
Compound 4: a limit, no number (the forecaster's own chance of this, stated with the estimate: 85%); the middle value lies beyond the limit too.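

In this assay compound 4 gives > 100 mg/kg as a limit of the assay and not a number. Among these compounds, compound 3 also stands only at a limit, so no step from compound 3 to compound 4 can be read. The compounds shown leave open whether fluoro in place of hydrogen on an aromatic carbon changes the dose in this assay at all on either core.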